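From a benzylamine to a dichlorophenyl thioether

The compounds below may be only part of what the source reports. "The series", "measured", "known", "first", "only" and "open" are said of these compounds alone.

Of the compounds shown here, three sharing one core have been tested in a functional assay on NCI-H322M cells (Homo sapiens) for inhibition, read by sulforhodamine B assay, with a stated time of 48 h; a lower number here means a stronger inhibitor of growth, a higher number a weaker inhibitor of growth. Compound 1 `Nc1cc(N)c2nc(-c3ccccc3)c(Oc3ccc(Cl)c(Cl)c3)nc2c1` gives 58900 nM, compound 2 `COc1ccc(CNc2nc3cc(N)cc(N)c3nc2-c2ccccc2)cc1OC` gives 47900 nM, and compound 3 `Nc1cc(N)c2nc(-c3ccccc3)c(NCc3ccc(F)cc3)nc2c1` gives 11500 nM. Compound 3 therefore stands lowest of the three, and both of its steps to the others lie beyond the scatter: a 5.1-fold lower number from compound 1 to compound 3 (0.71 log units; beyond the scatter), and a 4.2-fold lower number from compound 2 to compound 3 (0.62 log units; beyond the scatter).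

The next compound, compound 4 `Nc1cc(N)c2nc(-c3ccccc3)c(Sc3ccc(Cl)c(Cl)c3)nc2c1`, changes one place on compound 3: (3,4-dichlorophenyl)sulfanyl in place of (4-fluorobenzyl)amino on an aromatic carbon. This puts the 3,4-dichlorophenyl group of compound 1 back onto the core, joined through sulfur instead of oxygen. Within the data shown here, the step that bears most on this change is therefore the one from compound 1 to compound 3, which ran opposite to the present direction and was of modest size. The step from compound 2 to compound 3 concerns only the benzylic ring and bears less directly. Among the measured compounds shown here, no measured pair shows what swapping oxygen for sulfur does on its own, so compound 4 is expected to land close to compound 1, which means a rise from compound 3 in the assay of roughly a 4.3-fold higher number from compound 3 to compound 4 (0.64 log units; beyond the scatter). The value estimated for compound 4 in this assay is 50000 nM, within the range 15000 nM to 150000 nM.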

Compound 4, concentration for total growth inhibition: 35500 nM
Estimate against measurement, compound 4: 1.4-fold (0.15 log units) above; measured number inside the range.
By their numbers in this assay, from the lowest: compound 3; then compounds 4, 2 and 1 (each within the scatter of the next).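

In this assay, putting (3,4-dichlorophenyl)sulfanyl in place of (4-fluorobenzyl)amino on this aromatic carbon gives a 3.1-fold higher number from compound 3 to compound 4 (0.49 log units; beyond the scatter) and confirms, with a second compound, that a dichlorophenyl group joined through a single atom stands weaker here than the benzylamine of compound 3. Among these compounds, the exchange of oxygen for sulfur, which no earlier pair could show, gives a 1.7-fold lower number from compound 1 to compound 4 (0.22 log units; within the scatter) and so leaves compound 1 and compound 4 indistinguishable, meaning that the identity of this linking atom makes no measurable difference with this ring attached. Nothing available explains the gap between compound 3 and compound 4.

The step from compound 3 to compound 4 changes the linker and the ring substituents together, so the compounds shown cannot say which of the two accounts for the higher number. Going by these compounds, a (3,4-dichlorobenzyl)amino group or a (4-fluorophenyl)sulfanyl group at this position would separate those two parts of the change, and the effect of either group on growth inhibition remains open.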